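A few compounds are considered here, and "the series" means these few. Any claim that something is new, unique, unknown or untested is made for them only; others in the source may bear on it.

Three compounds of the series have numbers in a functional assay on MOLT-4 cells (Homo sapiens); on this read-out lower numbers stand for stronger inhibition and higher numbers for weaker inhibition. Compound 1 `Cn1ncc2c1[C@H](Cn1cnc3c(Cl)ncnc31)C[C@@H]2CO[Si](c1ccccc1)(c1ccccc1)C(C)(C)C` gives 3.2 ug/mL. Compound 3 `Cn1ncc2c1[C@@H](CO[Si](c1ccccc1)(c1ccccc1)C(C)(C)C)C[C@H]2Cn1cnc2c(O)ncnc21` gives 3.2 ug/mL; compound 1 and compound 3 thus show the same value. Compound 2 `CC(C)Nc1ncnc2c1ncn2C[C@@H]1C[C@H](CO)c2ccccc21` gives 24 ug/mL, the highest of the three: compound 1 and compound 3 both lie lower by a margin beyond the scatter, so compound 2 is the weakest inhibitor among the measured compounds.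

Compound 4 `CCCNc1ncnc2c1ncn2C[C@@H]1C[C@H](CO)c2ccccc21` is not yet measured. It differs from compound 2 in one place: propyl in place of isopropyl on a nitrogen on an aromatic ring. The two have the same atoms, joined differently. Going by the values given here, no pair of measured compounds differs in a single place, so nothing anchors the size of this change. The step is therefore expected to be small, no change at the digits printed from compound 2 to compound 4 (within the scatter), in no fixed direction and not beyond the scatter. For compound 4 the expected value in this assay is 24 ug/mL, with a range from 10 ug/mL to 60 ug/mL.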

Compound 4, half-maximal inhibitory concentration: 24 ug/mL
The estimate for compound 4 equals the measured number at the digits printed; measured number inside the range.
By their numbers in this assay, from the lowest: compounds 1 and 3 (each within the scatter of the next); then compounds 2 and 4 (each within the scatter of the next).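

In this assay, going by these compounds alone, going from isopropylamino to propylamino gives no change at the digits printed from compound 2 to compound 4 (within the scatter), the first step that can be read in one place. For this pair, the read-out does not separate the two arrangements of the same three carbons at this nitrogen. No available evidence bears on why these two compounds read alike.

This single pair is all that speaks for the position, so a longer chain such as hexyl, a cyclopropyl, a benzyl or an unsubstituted amine there could still shift the number in this assay. Compound 1 and compound 3 differ from compound 2 and compound 4 in more than one place, so those steps cannot be read.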